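The source may report more compounds than this note shows. Statements on the series, on what has been measured and on what is new or still open speak of the compounds shown alone.

Measured so far:
compound 1, `CC(C)n1nc(S(=O)(=O)c2cccc3ccccc23)c2cc(N3CCN(C)CC3)ccc21`, 1.8 nM
compound 2, `CN1CCN(c2ccc3c(c2)c(S(=O)(=O)c2cccc4ccccc24)nn3Cc2ccccc2)CC1`, 2 nM
compound 3, `CC(C)Cn1nc(S(=O)(=O)c2cccc3ccccc23)c2cc(N3CCN(C)CC3)ccc21`, 1.4 nM

All three share one core and differ only in the group carried on the aromatic nitrogen. In a functional assay on HeLa cells for antagonist activity at 5-hydroxytryptamine receptor 6 (Homo sapiens) (a higher number here means a weaker inhibitor, a lower number a stronger inhibitor), compound 3 gives the lowest number of the three, but its step from compound 1, a 1.3-fold lower number from compound 1 to compound 3 (0.11 log units; within the scatter), and its step from compound 2, a 1.4-fold lower number from compound 2 to compound 3 (0.15 log units; within the scatter), both sit within the scatter, so the three compounds cannot be told apart on these numbers.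

Compound 4, `CCn1nc(S(=O)(=O)c2cccc3ccccc23)c2cc(N3CCN(C)CC3)ccc21`, is not yet measured. It differs from compound 3 in one place: methyl in place of isopropyl on a saturated chain carbon bound to an aromatic nitrogen.

Going by the values given here, three measured steps bear on this change, all at the same position. a 1.1-fold higher number from compound 1 to compound 2 (0.05 log units; within the scatter) puts benzyl where isopropyl was; a 1.3-fold lower number from compound 1 to compound 3 (0.11 log units; within the scatter) puts isobutyl there; a 1.4-fold lower number from compound 2 to compound 3 (0.15 log units; within the scatter) puts isopropyl in place of phenyl on the chain carbon. None of them moved the number beyond the scatter, whether the group grew or changed shape. Among the compounds with values here, no measured step goes down to a group as small as ethyl, so the expectation rests on this flatness alone.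

For compound 4 the expected step is a 1.4-fold higher number from compound 3 to compound 4 (0.15 log units; within the scatter), which is to say no change beyond the scatter. Compound 4 is estimated at 2 nM, with a range from 0.8 nM to 5 nM.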

Compound 4, half-maximal inhibitory concentration: 1.7 nM
Beside the measured number, compound 4's estimate is 1.2-fold (0.07 log units) above it; the measured number falls inside the stated range.
By their numbers in this assay, from the lowest: compounds 3, 4, 1 and 2 (each within the scatter of the next).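

In this assay, the group on the aromatic nitrogen is now ethyl in compound 4, and the number still does not move beyond the scatter. Shortening isobutyl to ethyl gives a 1.2-fold higher number from compound 3 to compound 4 (0.08 log units; within the scatter) and going from isopropyl to ethyl gives a 1.1-fold lower number from compound 1 to compound 4 (0.02 log units; within the scatter), while replacing benzyl with ethyl gives a 1.2-fold lower number from compound 2 to compound 4 (0.07 log units; within the scatter) and removes the ring from this group altogether. The flat picture, which earlier covered only isopropyl, isobutyl and benzyl, therefore now reaches ethyl as well, and the four compounds cannot be told apart on these numbers. Nothing available explains why this position accepts such different groups with so little change.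

The groups shown here are all built from carbon and hydrogen alone, so it remains open whether an amine or a carboxylic acid on this nitrogen would leave the number equally flat. Also open, from the compounds shown here alone, is whether the flatness would survive a much longer chain, such as octyl, or the loss of the group altogether, with a bare hydrogen on that nitrogen.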